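Swapping the aryl on silicon: fluorophenyl to methylphenyl

A few compounds are considered here, and "the series" means these few. Any claim that something is new, unique, unknown or untested is made for them only; others in the source may bear on it.

Of the compounds shown here, two have been measured in a functional assay on liver (Sus scrofa) for inhibition of squalene monooxygenase (Homo sapiens), using microsomes; a lower number here means a stronger inhibitor, a higher number a weaker inhibitor. Compound 2 `CCN(C/C=C/C#CC(C)(C)C)Cc1cccc(OC[Si](C)(C)c2ccc(F)cc2)c1` gives 60 nM, the lower of the two numbers, while compound 1 `CCN(CC#CC#CC(C)(C)OC)Cc1cccc(OC[Si](C)(C)c2ccccc2C)c1` gives 70 nM in this assay; the gap between them lies within the usual scatter. Compound 3 `CCN(C/C=C/C#CC(C)(C)C)Cc1cccc(OC[Si](C)(C)c2ccccc2C)c1` is not yet measured. It differs from compound 2 by 2-methylphenyl in place of 4-fluorophenyl on a silicon. Within the data shown here, no step between measured compounds isolates this change, so no shift beyond the scatter is expected in either direction in this assay. Compound 3 is therefore estimated at 65 nM, with a range from 30 nM to 140 nM, meaning an expected step of a 1.1-fold higher number from compound 2 to compound 3 (0.03 log units; within the scatter).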

Compound 3, half-maximal inhibitory concentration: 30 nM
Compound 3: middle estimate off by 2.2-fold (0.34 log units), on the high side; the range from low to high includes it.
By their numbers in this assay, from the lowest: compounds 3, 2 and 1 (each within the scatter of the next, the first and the last beyond it).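

On the silicon, 2-methylphenyl in place of 4-fluorophenyl gives a 2.0-fold lower number from compound 2 to compound 3 (0.30 log units; within the scatter) in this assay, so this position accepts either aryl group without a shift that stands clear of the scatter. With 2-methylphenyl kept on the silicon, changing only the chain on the amine nitrogen gives a 2.3-fold lower number from compound 1 to compound 3 (0.37 log units; beyond the scatter), a modest step and the only one here beyond the scatter. Nothing available explains either step. Still open, as far as these compounds go, is whether a plain phenyl or a naphthyl on the silicon would move the number beyond the scatter. Also open, from the compounds shown here alone, is whether the chain of compound 1 would give the same step alongside 4-fluorophenyl.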